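The source may hold more compounds than are shown below. What is called first, only, known or untested is meant among the compounds shown, and "the series" means these compounds.

Compound 1 `O=C1Nc2ccccc2/C1=C/c1ccc(-c2cn(-c3cccc(F)c3)nn2)cc1`: > 20000 nM (a limit)
Compound 2 `O=C1Nc2ccccc2/C1=C/c1ccc(-c2cn(-c3ccc(F)cc3)nn2)cc1`: 16700 nM

Among the compounds with values here, in a functional assay on MKN-45 cells (Homo sapiens) for inhibition, read by CCK-8 assay, with a stated time of 24 h (on this read-out higher numbers stand for weaker inhibition and lower numbers for stronger inhibition), compound 2 gives 16700 nM, the only actual number so far. The entry for compound 1 is a limit of the assay. Compound 3 `O=C1Nc2ccccc2/C1=C/c1ccc(-c2cn(-c3ccccc3Cl)nn2)cc1` differs from compound 2 as follows: 2-chlorophenyl in place of 4-fluorophenyl on an aromatic nitrogen. Within the data shown here, one measured step bears on this change, also made on the aromatic nitrogen: an at least 1.1-fold lower number from compound 1 to compound 2 (0.07 log units; that floor lies within the scatter). Since that step does not clear the scatter, no shift beyond the scatter is expected in this assay. The expected change is a 1.1-fold higher number from compound 2 to compound 3 (0.03 log units; within the scatter). Compound 3 is estimated at 18000 nM, with an expected range from 9000 nM to 30000 nM.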

Compound 3, half-maximal inhibitory concentration: > 20000 nM
Compound 3: no number, only a limit (the forecaster's own chance of this, stated with the estimate: 45%); at least 1.1-fold (0.04 log units) between middle value and limit.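

In this assay compound 3 gives > 20000 nM as a limit and not a number. Within the data shown here, putting 2-chlorophenyl in place of 4-fluorophenyl on the aromatic nitrogen gives an at least 1.1-fold higher number from compound 2 to compound 3 (0.07 log units; that floor lies within the scatter) and so, for the first time with a chlorine on this phenyl, still shows no shift that clears the scatter. The step from compound 1 to compound 3 cannot be read, and the other step has only a floor because most of the values stand at one limit: the limit of > 20000 nM in this assay, at which 2 of the 3 values shown sit.

The compounds shown leave open whether any group on this nitrogen can bring the number well down. On these data alone, an amine or a carboxylic acid on the phenyl, or a longer chain in its place, remains untested by these values.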